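The compounds below may be only part of what the source reports. "The series", "measured", "known", "first", "only" and "open" are said of these compounds alone.

Two compounds of the series have been run in a functional assay on SV5A8 cells (Homo sapiens) for cytotoxicity (on this read-out lower numbers stand for stronger inhibition and higher numbers for weaker inhibition), and neither returns a number. Compound 1 `Cc1ccc2c(NCc3ccc(NC(=O)C4CCN(Cc5ccccc5)CC4)cc3)nc(N3CCC3)nc2c1` gives > 8500 nM in this assay, which is a limit of the assay and not a measured value. Compound 2 `COc1ccc(CN2CCC(C(=O)Nc3ccc(CNc4nc(N(C)C)nc5cc(C)ccc45)cc3)CC2)cc1` gives > 6180 nM in this assay, again a limit rather than a number. Where compound 2 stands can thus be stated only as a limit, recorded as the limit of > 6180 nM in this assay, at which 1 of the 2 values shown sits. The same holds for the other limit shown, (the limit of > 8500 nM in this assay, at which 1 of the 2 values shown sits). Compound 3 `CCCCN1CCC(C(=O)Nc2ccc(CNc3nc(N(C)C)nc4cc(C)ccc34)cc2)CC1` differs from compound 2 by propyl in place of 4-methoxyphenyl on a saturated chain carbon bound to an amine nitrogen in a ring. Going by the values given here, no step between measured compounds exists to size this change, so no direction beyond the scatter can be read from the data. With compound 2 sitting at a limit, compound 3 is expected to sit at one as well, the expected step from compound 2 to compound 3 being a step that the limit leaves unreadable from compound 2 to compound 3, and the estimated value for compound 3 is 15000 nM, with a range from 5000 nM to 60000 nM.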

Compound 3, half-maximal inhibitory concentration: > 10500 nM
Compound 3: no number, only a limit; the forecaster's own chance of this, stated with the estimate: 80%; the middle value is on the limit's open side.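

Going by these compounds alone, compound 2 and compound 3 both stand as limits in this assay, and no step between them can be read. The compounds shown leave open what values lie behind these limits and whether propyl in place of 4-methoxyphenyl shifts the read-out at all.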